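Cytotoxicity notes on a dichloronicotinamide piperidine series

The compounds below may be only part of what the source reports. "The series", "measured", "known", "first", "only" and "open" are said of these compounds alone.

Measured so far in an ADME assay on PBMC cells (Homo sapiens) for cytotoxicity; on this read-out higher numbers stand for lower toxicity in this test and lower numbers for higher toxicity in this test:
- compound 1 `CC(CCNC(=O)c1c(Cl)cncc1Cl)N1CCC(C(=O)c2ccc(Br)cc2)CC1`: 189000 nM
- compound 2 `COC(=O)c1cccc(OC(c2ccc(C(F)(F)F)cc2)C2CCN(C(C)CCNC(=O)c3c(Cl)cncc3Cl)CC2)n1`: 14600 nM
- compound 3 `CC(CCNC(=O)c1c(Cl)cncc1Cl)N1CCC(C(Oc2ccccn2)c2ccc(Br)cc2)CC1`: 33700 nM

Compound 2 stands lowest of the three in this assay, beyond the scatter from compound 3 and well beyond it from compound 1. Compound 4 `CC(CCNC(=O)c1c(Cl)cncc1Cl)N1CCC(C(Oc2cccc(F)c2)c2ccc(C(F)(F)F)cc2)CC1` has not yet been measured. It differs from compound 2 in one place: 3-fluorophenyl in place of 6-(methoxycarbonyl)pyridin-2-yl on an oxygen on a saturated carbon. Among the compounds with values here, no step between measured compounds matches this change, so the expectation rests on the spread of the three values alone. A moderate upward step is expected for compound 4, probably just beyond the scatter, since compound 3, which also carries an aryloxy group in that place, gives 33700 nM. The step from compound 2 to compound 4 is estimated as a 2.1-fold higher number from compound 2 to compound 4 (0.31 log units; beyond the scatter). Compound 4 is expected at 30000 nM, within 10000 nM to 90000 nM.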

Compound 4, half-maximal cytotoxic concentration: 5400 nM
For compound 4 the middle estimate is 5.6-fold (0.74 log units) above the measured one; the measured number lies below the stated range.
By their numbers in this assay, from the lowest: compound 4; then compound 2; then compound 3; then compound 1.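

In this assay the aryl group on this oxygen is not a silent position: 3-fluorophenyl in place of 6-(methoxycarbonyl)pyridin-2-yl gives a 2.7-fold lower number from compound 2 to compound 4 (0.43 log units; beyond the scatter) and moves the read-out toward higher toxicity in this test. The low number of compound 2 therefore does not depend on its 6-(methoxycarbonyl)pyridin-2-yl group, since compound 4 lacks that group and still reads lower. No measurement here accounts for this step.

The compounds shown leave open which part of the change carries the step: the methyl ester, the ring nitrogen or the fluorine. Going by these compounds, how a carboxylic acid or an amine on this aryl ring would read also remains open.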